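Chloro Substitution on the Benzyl Ester of Compound 1

The source may hold more compounds than are shown below. What is called first, only, known or untested is meant among the compounds shown, and "the series" means these compounds.

Measured so far:
Compound 1 `O=C(OCc1ccccc1)c1cccc(=O)[nH]1` in an assay on isolated protein for inhibition of matrix metalloproteinase-9 (Homo sapiens) (a lower number here means a stronger inhibitor, a higher number a weaker inhibitor), gives 69000 nM.
Compound 2 `COc1ccc(COC(=O)c2cccc(=O)[nH]2)cc1` in this assay gives 100000 nM.

Compound 1 has the lowest of the two numbers in this assay, but its nearest neighbour is compound 2, and the step of a 1.4-fold higher number from compound 1 to compound 2 (0.16 log units; within the scatter) lies within the scatter, so the two cannot be ordered. Compound 3 `O=C(OCc1cccc(Cl)c1)c1cccc(=O)[nH]1` has not yet been measured. It differs from compound 1 by chloro in place of hydrogen on an aromatic carbon, a chloro group meta to a large group on the six-membered aromatic ring of carbon only.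

Among the measured compounds shown here, the only measured step that bears on the question is the one from compound 1 to compound 2, where a methoxy group on the same ring produced a 1.4-fold higher number from compound 1 to compound 2 (0.16 log units; within the scatter), a change within the scatter. For the measured compounds named here, no chloro analogue has been measured, so nothing in the data points to a step beyond the scatter. Compound 3 is therefore expected to give 60000 nM in this assay, within a range from 20000 nM to 150000 nM. That estimate implies a 1.2-fold lower number from compound 1 to compound 3 (0.06 log units; within the scatter), a step not expected to exceed the scatter.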

Compound 3, half-maximal inhibitory concentration: 67000 nM
Estimate against measurement, compound 3: 1.1-fold (0.05 log units) below, within the range that was stated.
By their numbers in this assay, from the lowest: compounds 3, 1 and 2 (each within the scatter of the next).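

In this assay, chloro in place of hydrogen on an aromatic carbon, meta to a large group, gives a step that stays within the scatter (a 1.0-fold lower number from compound 1 to compound 3 (0.01 log units; within the scatter)), so this position accepts a chlorine atom with no readable change in the number. Among the compounds shown here, the earlier compounds offered only one substituent on this ring, the methoxy group of compound 2 (a 1.4-fold higher number from compound 1 to compound 2 (0.16 log units; within the scatter)), and compound 3 now adds a second substituent whose step from compound 1 also stays within the scatter, so neither replacement of hydrogen on this ring gives a step beyond it. Nothing shown here accounts for this result.

The compounds shown leave open whether any group on this ring can produce a step beyond the scatter, for example an amine or a carboxylic acid at the same place, or a longer chain bearing either of them. They also leave open whether chloro at another place on the ring would give a different number, and how changes to the rest of the core of compound 1 would read in this assay.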